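The compounds below may be only part of what the source reports. "The series", "measured", "known", "first", "only" and "open" are said of these compounds alone.

Measured compounds:
Compound 1 `Clc1cc(Cl)cc(CO[C@H]2CCCN(Cc3ccccc3)[C@H]2c2ccccc2)c1` in an assay on isolated protein for activation of cGMP-dependent protein kinase 1 (Homo sapiens), read by ADP-Glo, with stated times of 120 min and 40 min (a lower number here means that less compound is needed, a higher number that more compound is needed for the effect), gives > 200000 nM, a limit of the assay.
Compound 2 `Clc1cc(Cl)cc(CO[C@H]2CCCN(Cc3ncco3)[C@H]2c2ccccc2)c1` in this assay gives > 200000 nM, also a limit.
Compound 3 `CN1CCC[C@H](OCc2cc(Cl)cc(Cl)c2)[C@@H]1c1ccccc1` in this assay gives > 200000 nM, again a limit.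

Compound 3 thus stands only at a limit, as do the two other values shown (the limit of > 200000 nM in this assay, at which 3 of the 3 values shown sit). The steps a step that the two limits leave unreadable from compound 1 to compound 2, a step that the two limits leave unreadable from compound 1 to compound 3 and a step that the two limits leave unreadable from compound 2 to compound 3 therefore have no readable size. Compound 4 `COc1cc(C(=O)O)ccc1CN1CCC[C@H](OCc2cc(Cl)cc(Cl)c2)[C@@H]1c1ccccc1` differs from compound 3 in one place: 4-carboxy-2-methoxyphenyl in place of hydrogen on a saturated chain carbon bound to an amine nitrogen in a ring. None of the measured steps involves a group of this kind, and none has a readable size, so no direction can be drawn for the step to compound 4 from the shown numbers. Compound 4 is expected to sit near the same limit, with the step of a number no higher from compound 3 to compound 4 (the limit leaves the size open) estimated as small. The estimate for compound 4 is 200000 nM, ranging from 40000 nM to 1000000 nM.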

Compound 4, half-maximal effective concentration: 62000 nM
Beside the measured number, compound 4's estimate is 3.2-fold (0.51 log units) above it; the range from low to high includes it.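

The steps among compound 1, compound 2 and compound 3 cannot be read, since all three sit at one limit: the limit of > 200000 nM in this assay, at which 3 of the 4 values shown sit.

On a saturated chain carbon bound to an amine nitrogen in a ring, 4-carboxy-2-methoxyphenyl gives the first readable change, with an at least 3.2-fold lower number from compound 3 to compound 4 (0.50 log units; beyond the scatter). The same group also gives an at least 3.2-fold lower number from compound 2 to compound 4 (0.50 log units; beyond the scatter) in place of 1,3-oxazol-2-yl, and an at least 3.2-fold lower number from compound 1 to compound 4 (0.50 log units; beyond the scatter) in place of phenyl.

The compounds shown do not separate the carboxylic acid from the methoxy, as no group here carries only one of them. From the compounds shown here alone, how an amide or a longer chain ending in a carboxylic acid would read at this position stays open.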